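Removing an isopropyl group from compound 3

This account rests on a few compounds, and the source may have more. Where it says the series, first, only, none or still open, it means among the compounds named here.

Among the measured compounds shown here, in a functional assay on SK-OV-3 cells (Homo sapiens) for cytotoxicity (on this read-out higher numbers stand for weaker inhibition and lower numbers for stronger inhibition), compound 3 (`CCOC(=O)[C@@H](NC(=O)[C@@H](OC(=O)c1ccc(C)c2cc(OC)ccc12)[C@]1(C)CO1)C(C)C`) gives 2950 nM, the only true number so far. Compound 1 (`C[C@@]1([C@H](OC(=O)c2ccccc2)C(N)=O)CO1`) reads > 25000 nM, which is a limit of the assay and not a number. Compound 2 (`C[C@@]1([C@H](OC(=O)c2cnc3ccccc3n2)C(N)=O)CO1`) reads > 25000 nM, which is also a limit. For the measured compounds named here, compound 3 therefore stands alone as the one compound with a measured strength.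

Compound 4 (`CCOC(=O)CNC(=O)[C@@H](OC(=O)c1ccc(C)c2cc(OC)ccc12)[C@]1(C)CO1`) differs from compound 3 in one place: hydrogen in place of isopropyl on a saturated chain carbon bound to an amide-type nitrogen and a carbonyl carbon. In words, this is hydrogen in place of isopropyl on a saturated chain carbon bound to an amide-type nitrogen and a carbonyl carbon.

Going by the values given here, no measured pair in this set shows what such a change does, so any forecast is uncertain. In this assay, no step beyond the usual scatter is expected, with a slight lean towards weaker inhibition. The expected step, a 1.5-fold higher number from compound 3 to compound 4 (0.18 log units; within the scatter), is small. The starting point for the estimate is compound 3 at 2950 nM. Compound 4 is estimated at 4500 nM, with an expected range of 1500 nM to 15000 nM.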

Compound 4, half-maximal inhibitory concentration: 7300 nM
Compound 4: the middle estimate sits 1.6-fold (0.21 log units) below what was measured; the measured number falls inside the stated range.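

In this assay, among the compounds shown here, hydrogen in place of isopropyl on this saturated chain carbon gives a 2.5-fold higher number from compound 3 to compound 4 (0.39 log units; beyond the scatter), a modest weakening and the first true step in the set. The side group at this position therefore affects the read-out, although compound 4 still gives a measurable value without the isopropyl group. Compounds 1 and 2 each read as a limit of the assay and not as a number, so they could not show this: the limit of > 25000 nM in this assay, at which 2 of the 4 values shown sit.

With only hydrogen and isopropyl to compare, the compounds shown leave open how the value changes with other groups at this carbon, such as a methyl, a benzyl or a longer chain. They also do not show why the number moves, or whether the same step would appear with a carboxylic acid in place of the ethyl ester.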